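Swapping Fluoro for Ethoxy on a Shared Core

The compounds below may be only part of what the source reports. "The series", "measured", "known", "first", "only" and "open" are said of these compounds alone.

Three compounds share one core and differ only in the group on one aromatic carbon. In an assay on HEK293 cells with D(4) dopamine receptor (Homo sapiens) as the target, read by FLIPR (on this read-out higher numbers stand for larger maximal responses and lower numbers for smaller maximal responses), compound 1 `N#Cc1ccccc1N1CCN(Cc2nc3ccccc3[nH]2)CC1` gives 46%, compound 2 `O=[N+]([O-])c1ccccc1N1CCN(Cc2nc3ccccc3[nH]2)CC1` gives 40%, and compound 3 `Fc1ccccc1N1CCN(Cc2nc3ccccc3[nH]2)CC1` gives 42%. Compound 3 stands second highest of the three numbers, yet every gap is within the scatter: a number 6 percentage points lower from compound 1 to compound 2 (within the scatter), a number 4 percentage points lower from compound 1 to compound 3 (within the scatter), and a number 2 percentage points higher from compound 2 to compound 3 (within the scatter). Compound 4 `CCOc1ccccc1N1CCN(Cc2nc3ccccc3[nH]2)CC1` carries the change (ethoxy in place of fluoro on an aromatic carbon). Within the data shown here, no measured step involves an ethoxy group or any group holding a hydrogen-bond acceptor, so the three steps above are the only guide, and all of them fell within the scatter. The expected step in this assay is therefore no change at the digits printed from compound 3 to compound 4 (within the scatter), nothing beyond the scatter. Compound 4 is estimated at 42%, with a range from 30% to 55%.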

Compound 4, largest response reached (reported as efficacy), in percent of the reference or control that the assay uses: 31%
Beside the measured number, compound 4's estimate is 11 percentage points above it; low and high end bracket the measured number.
By their numbers in this assay, from the lowest: compounds 4, 2, 3 and 1 (each within the scatter of the next, the first and the last beyond it).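

Ethoxy on this aromatic carbon gives the first steps beyond the scatter in this series in this assay: a number 11 percentage points lower from compound 3 to compound 4 (beyond the scatter) and a number 15 percentage points lower from compound 1 to compound 4 (beyond the scatter). The result is not a clean break from all the earlier groups, however, as the step of a number 9 percentage points lower from compound 2 to compound 4 (within the scatter) shows. No supporting data here explain these steps. Going by these compounds, whether they follow from the length of the ethoxy chain or from its oxygen stays open. Methoxy, propoxy and ethyl groups on the same carbon would help separate the two.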